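A Methoxy Group Moved Along the Ring

A few compounds are considered here, and "the series" means these few. Any claim that something is new, unique, unknown or untested is made for them only; others in the source may bear on it.

Compound 1 `COc1ccccc1Sc1c[nH]c2ccc(Cl)cc12` is the reference. In an assay on isolated protein for inhibition of Indoleamine 2,3-dioxygenase 1 (Homo sapiens), read by HPLC, with a stated time of 60 min, in the presence of a further agent that is not named here (on this read-out lower numbers stand for stronger inhibition and higher numbers for weaker inhibition), compound 1 gives 17500 nM. Compound 2 `COc1ccccc1Cc1c[nH]c2ccc(Cl)cc12` joins the two rings through carbon instead of sulfur, and in this assay compound 2 gives 63000 nM. Compound 3 `Clc1ccc2[nH]cc(Sc3ccccc3)c2c1` lacks the methoxy group. On these data alone, for compound 3 this assay reports only a limit, > 200000 nM, so its true number is unknown. The step of an at least 11-fold higher number from compound 1 to compound 3 (1.05 log units; beyond the scatter) shows that losing the methoxy weakened inhibition sharply, a step resting on (the limit of > 200000 nM in this assay, at which 1 of the 3 values shown sits). Compound 4 `COc1cccc(Sc2c[nH]c3ccc(Cl)cc23)c1` restores the group at another place: methoxy in place of hydrogen on an aromatic carbon. Among the compounds with values here, no measured step tells whether a methoxy there helps as much as in compound 1. The expected step of an at least 3.3-fold lower number from compound 3 to compound 4 (0.52 log units; beyond the scatter) is therefore a partial recovery. Compound 4 is estimated at 60000 nM, between 15000 nM and 200000 nM.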

Compound 4, half-maximal inhibitory concentration: 21000 nM
Compound 4: the middle estimate sits 2.9-fold (0.46 log units) above what was measured; measured number inside the range.
By their numbers in this assay, from the lowest: compounds 1 and 4 (each within the scatter of the next); then compound 2. At a limit, above all of these: compound 3.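

Placed on this carbon, meta to a large group, methoxy gives an at least 9.5-fold lower number from compound 3 to compound 4 (0.97 log units; beyond the scatter), a step whose size rests on a limit: the limit of > 200000 nM in this assay, at which 1 of the 4 values shown sits. The benefit of methoxy is therefore not tied to the place it holds in compound 1. In this assay compound 1 gives 17500 nM and compound 4 gives 21000 nM, values within the scatter of each other.

On these data alone, whether a hydroxyl, an amine or a longer chain such as ethoxy would serve as well at this place remains open. So does how a carbon link instead of sulfur would fare with methoxy here.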